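The source may report more compounds than this note shows. Statements on the series, on what has been measured and on what is new or still open speak of the compounds shown alone.

Compound 2, `O=C(O)Cc1sc(Nc2ccc(Cl)cc2)nc1-c1ccc(F)cc1`, was tested in an in vitro functional assay on HEK285-7 cells for antagonist activity at prostaglandin D2 receptor 2 (Homo sapiens), read by BRET and beta-arrestin recruitment; a higher number here means a larger maximal response, a lower number a smaller maximal response. For compound 2 the result is only a limit, > 70%. Two related compounds were measured in the same way. Compound 1, `COc1ccccc1Nc1nc(-c2ccc(F)cc2)c(CC(=O)O)s1`, likewise gives only a limit in this assay, > 70%. Compound 3, `COc1ccc(-c2nc(-c3ccccc3)c(CC(=O)O)s2)cc1`, also gives a limit in this assay, > 70%. Of these three, one pair differs in a single place: going from compound 1 to compound 2 puts 4-chlorophenyl in place of 2-methoxyphenyl on a nitrogen on an aromatic ring, and that gives a step that the two limits leave unreadable from compound 1 to compound 2 because of the limit of > 70% in this assay, at which 3 of the 3 values shown sit. Within the data shown here, compound 2 therefore stands exactly where every measured value stands, and no measured step can show how far the maximal response moves when the structure is changed.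

The next compound, compound 4, `O=C(O)Cc1sc(Cc2ccccc2Br)nc1-c1ccc(F)cc1`, alters compound 2 in one place: 2-bromobenzyl in place of (4-chlorophenyl)amino on an aromatic carbon. Among the measured compounds shown here, no measured step bears on this change, since the one step available is unreadable. With no direction to read from the data, the step from compound 2 to compound 4 is expected to be a step that the limit leaves unreadable from compound 2 to compound 4 in this assay. Compound 4 is accordingly estimated at 75%, within a range from 45% to 95%.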

Compound 4, largest response reached (reported as efficacy), in percent of the reference or control that the assay uses: > 70%
Compound 4 was reported as a limit (the forecaster's own chance of this, stated with the estimate: 60%); the middle value lies beyond the limit too.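

Putting 2-bromobenzyl in place of (4-chlorophenyl)amino gives no readable step from compound 2 to compound 4 in this assay, because both results are limits and not numbers: the limit of > 70% in this assay, at which 4 of the 4 values shown sit. The compounds shown leave open where the true maximal response of each one lies, and whether any of these structural changes moves it at all.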